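A few compounds are considered here, and "the series" means these few. Any claim that something is new, unique, unknown or untested is made for them only; others in the source may bear on it.

Compounds measured in an ADME assay on Huh-7 cells (Homo sapiens) for cytotoxicity; on this read-out lower numbers stand for higher toxicity in this test and higher numbers for lower toxicity in this test:

compound 1 `NC(=S)N1CCCc2c(OCCCCCOc3cccc4ccccc34)cccc21`: > 50000 nM, a limit of the assay
compound 2 `NC(=S)N1CCc2c(OCCCCCOc3ccc(Cl)cc3)cccc21`: > 50000 nM, a limit of the assay
compound 3 `O=C(NC(=S)N1CCc2cccc(OCc3ccccc3)c21)c1ccccc1`: > 50000 nM, a limit of the assay

Compound 2 stands where every compound of the set stands in this assay: its value is a limit, not a number, and the same holds for compound 1 and for compound 3, so that the limit of > 50000 nM in this assay, at which 3 of the 3 values shown sit, sums up the whole picture. Among the measured compounds shown here, no step between measured compounds is available, and compound 2 can neither be ranked against compound 1 nor against compound 3; what the three values show is only that none of them reached a measurable concentration.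

Compound 4 `N#Cc1cccc(C(=O)NC(=S)N2CCc3c(OCCCCCOc4ccc(Cl)cc4)cccc32)c1` differs from compound 2 in one place: (3-cyanophenyl)carbonyl in place of hydrogen on an amide-type nitrogen. For the measured compounds named here, the set holds no pair that would put a size on such a change, and compound 3, which carries a benzoyl group on the same kind of nitrogen, likewise sits at the limit in this assay.

Going by the values given here, with three limits and no measured step, the expectation for the step from compound 2 to compound 4 in this assay is none beyond the scatter, a step that the limit leaves unreadable from compound 2 to compound 4. Compound 4 is therefore estimated at 60000 nM in this assay, within 20000 nM to 200000 nM, most likely reported as a limit again.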

Compound 4, half-maximal cytotoxic concentration: 9750 nM
The estimate for compound 4 lay 6.2-fold (0.79 log units) above the measured number; measured number below the stated range.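

In this assay, among the compounds shown here, compound 4 gives the only value of the set that is a number rather than a limit, and this comes with a single change: (3-cyanophenyl)carbonyl in place of hydrogen on the amide-type nitrogen whose other neighbour is the thiocarbonyl carbon. The change brings an at least 5.1-fold lower number from compound 2 to compound 4 (0.70 log units; beyond the scatter), so this nitrogen is a place where a substituent can move the read-out towards higher toxicity in this test, and the step is a real one even though only its smallest size can be read. Compound 1, compound 2 and compound 3 each remain at a limit, not a number: the limit of > 50000 nM in this assay, at which 3 of the 4 values shown sit.

The compounds shown do not separate the carbonyl from the 3-cyanophenyl part, so it stays open whether a small acetyl group on the same nitrogen would give a step of similar size. On these data alone, it also stays open whether a carboxylic acid or an amine in place of the nitrile on the same group would keep the value of compound 4 near 9750 nM or lose the step.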